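The source may hold more compounds than are shown below. What is called first, only, known or untested is meant among the compounds shown, and "the series" means these compounds.

Compound 1 `NS(=O)(=O)c1ccc(/N=C2\NC(=O)/C(=C3/C(=O)Nc4ccc(F)cc43)S2)cc1`; compound 2 `NS(=O)(=O)c1ccc(/N=C2\NC(=O)/C(=C3/C(=O)Nc4ccc(Br)cc43)S2)cc1`; compound 3 `NS(=O)(=O)c1cccc(/N=C2\NC(=O)/C(=C3/C(=O)Nc4ccc(Cl)cc43)S2)c1`; compound 4 `COc1ccc2c(c1)/C(=C1/S/C(=N/c3ccc(S(N)(=O)=O)cc3)NC1=O)C(=O)N2`, not yet measured.

In a functional assay on MCF7 cells (Homo sapiens) for antiproliferative activity, read by MTT assay (on this read-out lower numbers stand for stronger inhibition and higher numbers for weaker inhibition), compound 1 gives 20500 nM. In this assay compound 2 gives 11300 nM. For compound 3 this assay reports only a limit, > 200000 nM, and no number. Compound 2 is thus one of two compounds with a number, and its nearest neighbour is compound 1, with a 1.8-fold lower number from compound 1 to compound 2 (0.26 log units; within the scatter).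

The step to compound 4 is methoxy in place of bromo on an aromatic carbon. Going by the values given here, the only measured step that bears on it is the halogen swap at the same position, a 1.8-fold lower number from compound 1 to compound 2 (0.26 log units; within the scatter), which stayed within the scatter; no measured step involves a methoxy group, so there is nothing to say how a non-halogen substituent at this position behaves. Among the compounds with values here, the expectation therefore rests on the one within-scatter step, and the step from compound 2 to compound 4 in this assay is expected to be small, a 1.3-fold higher number from compound 2 to compound 4 (0.12 log units; within the scatter), with no clear direction. For compound 4 in this assay the estimated value is 15000 nM, with an expected range from 5000 nM to 45000 nM.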

Compound 4, half-maximal inhibitory concentration: 125000 nM
Compound 4: middle estimate off by 8.3-fold (0.92 log units), on the low side; measured number outside the range, above it.
By their numbers in this assay, from the lowest: compounds 2 and 1 (each within the scatter of the next); then compound 4. At a limit, above all of these: compound 3.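

Going by these compounds alone, at this position, the swap of fluoro for bromo had stayed within the scatter in this assay, so the earlier compounds gave no sign that the substituent here mattered. Methoxy in place of bromo gives an 11-fold higher number from compound 2 to compound 4 (1.04 log units; beyond the scatter), and methoxy in place of fluoro gives a 6.1-fold higher number from compound 1 to compound 4 (0.79 log units; beyond the scatter); both steps lie beyond the scatter, so the two halogens do not speak for every group on this aromatic carbon. Compound 3 is the only one reported as a limit and not as a number, while compound 4 keeps a number in this read-out: the limit of > 200000 nM in this assay, at which 1 of the 4 values shown sits.

Going by these compounds, it remains open whether the higher number belongs to methoxy alone or would also appear with other non-halogen groups at this position, such as a methyl, a hydroxyl or an amine. Compound 3 differs from the others in more than one place, so steps to it cannot be read, and how chloro behaves at this position on the core of compound 2 also stays unanswered.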